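Replacing the triazole with piperidine on the shared core

A few compounds are considered here, and "the series" means these few. Any claim that something is new, unique, unknown or untested is made for them only; others in the source may bear on it.

Three compounds share one core and differ only in the group attached to the six-membered carbon ring. Compound 1 `CCC(C)(C)Cc1c[nH]c(CCc2ccc(-c3cccc(C#N)n3)cc2)n1` gives 140 nM in an in vitro assay on CHO cells for displacement of a labelled ligand from Bombesin receptor subtype-3 (Homo sapiens), read by scintillation counting, with a stated time of 2 h; a lower number here means a stronger inhibitor, a higher number a weaker inhibitor. Compound 2 `CCC(C)(C)Cc1c[nH]c(CCc2ccc(-c3ccc(F)cn3)cc2)n1` gives 19 nM, and compound 3 `CCC(C)(C)Cc1c[nH]c(CCc2ccc(-n3cncn3)cc2)n1` gives 340 nM, the highest number of the three. The steps show how much this position matters: a 7.4-fold lower number from compound 1 to compound 2 (0.87 log units; beyond the scatter), a 2.4-fold higher number from compound 1 to compound 3 (0.39 log units; beyond the scatter), and an 18-fold higher number from compound 2 to compound 3 (1.25 log units; beyond the scatter). Compound 4 `CCC(C)(C)Cc1c[nH]c(CCc2ccc(N3CCCCC3)cc2)n1` has not yet been measured. It differs from compound 3 in one place: piperidin-1-yl in place of 1H-1,2,4-triazol-1-yl on an aromatic carbon. All three measured steps bear on this change, since each swaps the group at the same position, and two of them were modest while one was large. Among the compounds with values here, a saturated ring of this kind has no measured counterpart here, so the direction is uncertain, but the large spread among the aromatic groups suggests the number will move. Compound 4 is expected to give about 150 nM, within 40 nM to 600 nM. The expected step from compound 3 to compound 4 is a 2.3-fold lower number from compound 3 to compound 4 (0.36 log units; beyond the scatter).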

Compound 4, half-maximal inhibitory concentration: 28 nM
Compound 4: middle estimate off by 5.4-fold (0.73 log units), on the high side; the measured number lies below the stated range.
By their numbers in this assay, from the lowest: compounds 2 and 4 (each within the scatter of the next); then compound 1; then compound 3.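

Among these compounds, an aromatic ring on this carbon is not needed for a low number in this assay: piperidin-1-yl, a six-membered non-aromatic ring, gives a 12-fold lower number from compound 3 to compound 4 (1.08 log units; beyond the scatter) and a 5.0-fold lower number from compound 1 to compound 4 (0.70 log units; beyond the scatter) within this small set. Set against 5-fluoropyridin-2-yl, the same group gives a 1.5-fold higher number from compound 2 to compound 4 (0.17 log units; within the scatter), so compound 2 and compound 4 cannot be told apart here, although one carries an aromatic ring at this position and the other a non-aromatic one. Nothing available explains why the number moves with these swaps.

The compounds shown leave open whether piperidin-1-yl is special among non-aromatic rings, a question that morpholin-4-yl or cyclohexyl on the same carbon would address. They also leave open whether an open-chain amine such as diethylamino would serve as well as a ring.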